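Chloro on the phenyl of compound 2

The source may report more compounds than this note shows. Statements on the series, on what has been measured and on what is new or still open speak of the compounds shown alone.

In a functional assay on SF-268 cells (Homo sapiens) for inhibition, with a stated time of 48 h (on this read-out higher numbers stand for weaker inhibition of growth and lower numbers for stronger inhibition of growth), compound 1 (`COc1c(C(=O)/C=C/c2ccc(Cl)cc2)c(O)c(Br)c2occc12`) gives 3500 nM as its reading, and compound 2 (`C=CCc1c(O)c(C(=O)/C=C/c2ccccc2)c(OC)c2ccoc12`) gives 2800 nM as its reading. Going by the values given here, these two values lie within the usual scatter of each other, so compound 2 does not stand apart from the only other number. Compound 3 (`C=CCc1c(O)c(C(=O)/C=C/c2ccc(Cl)cc2)c(OC)c2ccoc12`) differs from compound 2 by one change, phenyl to 4-chlorophenyl, with chloro in place of hydrogen on an aromatic carbon, para to a large group (chloro in place of hydrogen on an aromatic carbon). Among the compounds with values here, no measured pair shows this change on its own, so the data give no size for it. The expectation in this assay is no step beyond the scatter and no firm direction. The estimated shift runs a 1.1-fold lower number from compound 2 to compound 3 (0.03 log units; within the scatter) and stays inside the scatter. For compound 3 the estimated value is 2600 nM with 1100 nM to 6000 nM as its expected range.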

Compound 3, concentration for 50% growth inhibition: 3250 nM
For compound 3 the middle estimate is 1.3-fold (0.10 log units) below the measured one; low and high end bracket the measured number.
By their numbers in this assay, from the lowest: compounds 2, 3 and 1 (each within the scatter of the next).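

In this assay, going by these compounds alone, chloro in place of hydrogen on the phenyl gives a 1.2-fold higher number from compound 2 to compound 3 (0.06 log units; within the scatter), so this first matched pair for the change shows no step that stands clear of the scatter. The second pair, allyl in place of bromo on an aromatic carbon with the 4-chlorophenyl kept, gives a 1.1-fold lower number from compound 1 to compound 3 (0.03 log units; within the scatter), so that exchange cannot be told apart from the scatter either. Nothing at hand bears on why the three readings stay together.

Going by these compounds, whether an amine or a carboxylic acid on the same aromatic carbon, or a longer chain in place of allyl, would move the reading remains open. Every step so far lies within the scatter, so the compounds shown do not yet identify any change that separates compounds on this read-out.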